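A few compounds are considered here, and "the series" means these few. Any claim that something is new, unique, unknown or untested is made for them only; others in the source may bear on it.

Of the compounds shown here, two of a shared core have been measured so far. Compound 1 `COc1cc(C(=O)c2sc(-c3ccc([N+](=O)[O-])cc3)cc2N)cc(OC)c1OC` gives 99 nM in a functional assay on CCRF-CEM cells (Homo sapiens) for antiproliferative activity (on this read-out higher numbers stand for weaker inhibition and lower numbers for stronger inhibition), while compound 2 `COc1cc(C(=O)c2sc(-c3ccccc3)cc2N)cc(OC)c1OC` gives 4.5 nM in this assay. Among the compounds with values here, the one change between them, hydrogen in place of nitro on an aromatic carbon, brings a 22-fold lower number from compound 1 to compound 2 (1.34 log units; beyond the scatter). Within the data shown here, compound 2 therefore stands at the lowest of the two numbers, with compound 1 as its only neighbour, a step beyond the scatter away.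

Compound 3 `COc1cc(C(=O)c2sc(-c3cccs3)cc2N)cc(OC)c1OC` is the next compound. Compared with compound 2 it shows (thiophen-2-yl in place of phenyl on an aromatic carbon). Among the measured compounds shown here, the only measured step, the one from compound 1 to compound 2, concerns a group attached to the phenyl ring, not a swap of the ring itself, so it bears on this change only loosely; it shows that what sits in this part of the molecule can move the number strongly, but it gives no direction for exchanging phenyl for thiophen-2-yl. The expected step of a 1.1-fold higher number from compound 2 to compound 3 (0.05 log units; within the scatter) is therefore small, within the scatter. Compound 3 is expected to give about 5 nM, between 1.5 nM and 17 nM.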

Compound 3, half-maximal inhibitory concentration: 9.4 nM
Estimate against measurement, compound 3: 1.9-fold (0.27 log units) below, within the range that was stated.
By their numbers in this assay, from the lowest: compound 2; then compound 3; then compound 1.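

In this assay, the earlier step changed only a group on the phenyl ring, whereas this one exchanges the whole ring on the aromatic carbon next to the ring sulfur, and the result is a modest rise (a 2.1-fold higher number from compound 2 to compound 3 (0.32 log units; beyond the scatter)). So this position does not demand phenyl: a five-membered aromatic ring with a sulfur keeps the number far closer to that of compound 2 than the nitro group of compound 1 does, and thiophen-2-yl in place of 4-nitrophenyl gives a large drop (an 11-fold lower number from compound 1 to compound 3 (1.02 log units; beyond the scatter)). Nothing measured here explains why phenyl gives the lowest number of the three or why thiophen-2-yl falls so near it.

The compounds shown leave open how other groups on the phenyl ring, such as an amine, a methoxy group or a carboxylic acid, would compare with nitro. They also leave open whether an aromatic ring is needed at this position at all, or whether a saturated ring such as cyclohexyl or a simple alkyl chain could take its place.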